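Cytotoxicity read-out in the piperidine amide series: compound 3

The compounds below may be only part of what the source reports. "The series", "measured", "known", "first", "only" and "open" are said of these compounds alone.

The series shares a core carrying two trifluoromethyl groups, varied at the aryl group on the amide-type nitrogen. Compound 1 `C=CCOc1cccc(NC(=O)C2CCCN(C(=O)c3cc(C(F)(F)F)cc(C(F)(F)F)c3)C2)c1` is the allyloxy member; in an ADME assay on PC-3 cells (Homo sapiens) for cytotoxicity, read by WST assay, tested at 100 uM (on this read-out higher numbers stand for more inhibition at the one concentration tested (going by the name of the read-out) and lower numbers for less inhibition), compound 1 gives 0%. Compound 2 `Cc1nc(-c2cccc(NC(=O)C3CCCN(C(=O)c4cc(C(F)(F)F)cc(C(F)(F)F)c4)C3)c2)cs1` carries the 2-methyl-1,3-thiazol-4-yl group instead, and in this assay compound 2 gives 1%. The step of a number 1 percentage points higher from compound 1 to compound 2 (within the scatter) shows that this exchange left the read-out unchanged within the scatter. Among the two numbers known so far compound 2 stands highest, with compound 1 within the scatter of it, so no order can be claimed.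

Compound 3 `O=C(Nc1ccc(Cl)cn1)C1CCCN(C(=O)c2cc(C(F)(F)F)cc(C(F)(F)F)c2)C1` is the next member, differing from compound 2 by 5-chloropyridin-2-yl in place of 3-(2-methyl-1,3-thiazol-4-yl)phenyl on an amide-type nitrogen. Going by the values given here, the only step recorded, a number 1 percentage points higher from compound 1 to compound 2 (within the scatter), sits at the same place and was flat, and both known values lie at the floor of the read-out. No step beyond the scatter is therefore expected in this assay for compound 3; the step of a number 2 percentage points higher from compound 2 to compound 3 (within the scatter) is the estimated change. Compound 3 is estimated at 3%, in a range from -8% to 15%.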

Compound 3, a percentage reported as inhibition, at one concentration (the size of the read-out at that concentration, not a potency): 0%
The estimate for compound 3 lay 3 percentage points above the measured number, and the stated range covers the measured number.
By their numbers in this assay, from the lowest: compounds 1, 3 and 2 (each within the scatter of the next).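

Exchanging the whole aryl group on the amide-type nitrogen, not just the group carried on the phenyl ring, still leaves the read-out in this assay within the scatter: the step is a number 1 percentage points lower from compound 2 to compound 3 (within the scatter), and against the allyloxy member it is no change at the digits printed from compound 1 to compound 3 (within the scatter). With a six-membered aromatic ring with a hetero atom and a chlorine in place of the phenyl ring, and with the 2-methyl-1,3-thiazol-4-yl group gone, the number in this read-out therefore stays level, with no step beyond the scatter. Three different aryl groups at this place now give numbers within the scatter of one another, and no information on why this is so is available here.

On these data alone, it remains open whether any group at this nitrogen can move the read-out at all, for example an aryl group bearing an aliphatic amine or a carboxylic acid, or a longer alkyl chain in place of the aryl group. Also open, as far as these compounds go, is whether the read-out responds to a change elsewhere in the shared core, such as methoxy groups in place of the two trifluoromethyl groups.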